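Urea series permeability notes: from compound 2 to compound 3

A few compounds are considered here, and "the series" means these few. Any claim that something is new, unique, unknown or untested is made for them only; others in the source may bear on it.

Among the measured compounds shown here, in an ADME assay for permeability, using PAMPA, at pH 7.4 (on this read-out lower numbers stand for lower permeability and higher numbers for higher permeability), compound 2 `COC(=O)c1cccc(NC(=O)Nc2cc(C)nc3ccccc23)c1` gives 746 10^-6 cm/s, the higher of the two numbers measured so far. Compound 1 `CCc1ccc(NC(=O)Nc2cc(C)nc3ccccc23)cc1` gives 535 10^-6 cm/s in this assay, and the gap between the two values is within the scatter, so the pair shows no real difference. Compound 3 `Cc1cc(NC(=O)Nc2cccc(OC(F)(F)F)c2)c2ccccc2n1` has not yet been measured in this assay. It differs from compound 2 by trifluoromethoxy in place of methoxycarbonyl on an aromatic carbon. For the measured compounds named here, both measured compounds sit at high readings in this assay with no step beyond the scatter between them, and the data hold no measured step that would point to a shift when the methoxycarbonyl is exchanged for trifluoromethoxy. The step of a 1.1-fold higher number from compound 2 to compound 3 (0.03 log units; within the scatter) is therefore expected to lie within the scatter. Compound 3 is estimated at 800 10^-6 cm/s in this assay, with a range from 450 10^-6 cm/s to 1400 10^-6 cm/s.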

Compound 3, apparent permeability: 464 10^-6 cm/s
Compound 3: the middle estimate sits 1.7-fold (0.24 log units) above what was measured; the measured number falls inside the stated range.
By their numbers in this assay, from the lowest: compounds 3, 1 and 2 (each within the scatter of the next).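

In this assay, among the compounds shown here, the exchange gives a 1.6-fold lower number from compound 2 to compound 3 (0.21 log units; within the scatter), the only measured step at this position, and it stays within the scatter. On this aromatic carbon, meta to a large group, methoxycarbonyl and trifluoromethoxy therefore cannot be told apart on this read-out, even though the change replaces a group with a double bond outside aromatic rings and 2 hydrogen-bond acceptors with one that has none of that double bond, 1 hydrogen-bond acceptor and 3 fluorine atoms. Nothing measured alongside these readings gives any explanation for this result.

The compounds shown leave open whether a carboxylic acid or an amine on this aromatic carbon would read apart from these two groups. From the compounds shown here alone, whether trifluoromethoxy and methoxycarbonyl would also stay within the scatter of each other on a different carbon of this ring also remains open.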